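Benzofuran in place of thiophene at a limit compound

A few compounds are considered here, and "the series" means these few. Any claim that something is new, unique, unknown or untested is made for them only; others in the source may bear on it.

Compound 1 `COc1ncnc2c1c(-c1cc3ccccc3o1)cn2[C@@H]1O[C@H](CO)[C@@H](O)[C@H]1O` gives 20900 nM here
Compound 2 `CNc1ncnc2c1c(-c1ccco1)cn2[C@@H]1O[C@H](CO)[C@@H](O)[C@H]1O` gives 220 nM here
Compound 3 `CNc1ncnc2c1c(-c1ccsc1)cn2[C@@H]1O[C@H](CO)[C@@H](O)[C@H]1O` gives > 20000 nM here

All three values come from a functional assay on K562 cells (Homo sapiens), read by MTT assay, with a stated time of 72 h (on this read-out lower numbers stand for stronger inhibition and higher numbers for weaker inhibition), in this series. Compound 3 stands at > 20000 nM as a limit and not a number. Among the compounds with values here, the starting point of the next step is therefore open on one side, with the limit of > 20000 nM in this assay, at which 1 of the 3 values shown sits, so far.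

Compound 4 `CNc1ncnc2c1c(-c1cc3ccccc3o1)cn2[C@@H]1O[C@H](CO)[C@@H](O)[C@H]1O` follows from compound 3 by one change on the shared core: 1-benzofuran-2-yl in place of thiophen-3-yl on an aromatic carbon and nothing else. Within the data shown here, the only measured step at this place is an at least 90-fold higher number from compound 2 to compound 3 (1.95 log units; beyond the scatter) and it shows that the group here can move the number a long way. Compound 1 also carries 1-benzofuran-2-yl and gives 20900 nM in this assay but differs from compound 4 elsewhere on the core, so it gives only a loose guide.

A lower number in this assay is expected, by a step well short of the measured one, and a result at the limit remains possible. The estimate means an at least 4.0-fold lower number from compound 3 to compound 4 (0.60 log units; beyond the scatter) as the expected move. Compound 4 is estimated at 5000 nM as a middle value. For compound 4 the expected range runs from 600 nM to 30000 nM in this estimate.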

Compound 4, half-maximal inhibitory concentration: > 20000 nM
Compound 4 gave a limit, no number (the forecaster's own chance of this, stated with the estimate: 30%); at least 4.0-fold (0.60 log units) between middle value and limit.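

In this assay, a second group in place of furan-2-yl on this aromatic carbon gives an at least 90-fold higher number from compound 2 to compound 4 (1.95 log units; beyond the scatter), so the loss seen with thiophen-3-yl is not confined to that group, and 1-benzofuran-2-yl, with its added six-membered aromatic ring of carbon only, does not recover the activity. Compound 4 gives > 20000 nM, which is a limit and not a number. The steps to compound 4 from compound 3 and from compound 1 cannot be read, so thiophen-3-yl and 1-benzofuran-2-yl cannot be ranked against each other, the exchange of methoxy for methylamino has no readable size, and the series now rests in part at the edge of the read-out: the limit of > 20000 nM in this assay, at which 2 of the 4 values shown sit.

Among the methylamino compounds shown, only compound 2 gives a number, 220 nM, and one number cannot show which feature of furan-2-yl matters at this place. From the compounds shown here alone, whether furan-3-yl or thiophen-2-yl on the same carbon would stay in the measurable range remains open, and either would separate the ring hetero atom from the point of attachment.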